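Amidine replaced by dimethylaminomethyl on the pyridine ring

A few compounds are considered here, and "the series" means these few. Any claim that something is new, unique, unknown or untested is made for them only; others in the source may bear on it.

Measured compounds:
compound 1, `CC(C)(C)c1ccc(NC(=O)c2ccc(-c3ncccc3NC3CCCC3)cc2)cc1`: 190 nM
compound 2, `CC(C)(C)c1ccc(NC(=O)c2ccc(-c3ncccc3NS(C)(=O)=O)cc2)cc1`: 152 nM
compound 3, `CC(C)(C)c1ccc(NC(=O)c2ccc(-c3ncccc3C(=N)N)cc2)cc1`: > 4000 nM

In a functional assay for antagonist activity at transient receptor potential cation channel subfamily V member 1 (Homo sapiens), read by FLIPR (on this read-out higher numbers stand for weaker inhibition and lower numbers for stronger inhibition), compound 1 gives 190 nM. Compound 2 gives 152 nM, and the step of a 1.3-fold lower number from compound 1 to compound 2 (0.10 log units; within the scatter) stays within the scatter. For compound 3 the assay reports only a limit, > 4000 nM, so its true value is not known as a number. The two steps leading to it, an at least 21-fold higher number from compound 1 to compound 3 (1.32 log units; beyond the scatter) and an at least 26-fold higher number from compound 2 to compound 3 (1.42 log units; beyond the scatter), are both large, which places compound 3 at the weak end of the three compounds (the limit of > 4000 nM in this assay, at which 1 of the 3 values shown sits).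

Compound 4, `CN(C)Cc1cccnc1-c1ccc(C(=O)Nc2ccc(C(C)(C)C)cc2)cc1`, is not yet measured. It differs from compound 3 by a group of 4 heavy atoms (3 carbon, 1 nitrogen; no ring) in place of a group of 3 heavy atoms (1 carbon, 2 nitrogen; no ring), on an aromatic carbon. Among the compounds with values here, both large measured steps concern the arrival of the same group that now leaves; neither compound 1 nor compound 2 carries the group that enters, so no measured step reports on it directly. What the data do show is that removing that group from the position where it sits has gone together with large changes, so a return toward the range of compound 1 and compound 2 is expected, though with wide uncertainty. The expected step is an at least 6.6-fold lower number from compound 3 to compound 4 (0.82 log units; beyond the scatter). For compound 4 the estimate in this assay is 600 nM, with a range from 120 nM to 4000 nM.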

Compound 4, half-maximal inhibitory concentration: 746 nM
Compound 4: the middle estimate sits 1.2-fold (0.09 log units) below what was measured; measured number inside the range.
By their numbers in this assay, from the lowest: compounds 2 and 1 (each within the scatter of the next); then compound 4. At a limit, above all of these: compound 3.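

Compound 3 is held at a limit in this assay, not at a number: the limit of > 4000 nM in this assay, at which 1 of the 4 values shown sits.

Against that limit, an at least 5.3-fold lower number from compound 3 to compound 4 (0.72 log units; beyond the scatter), so this aromatic carbon, two atoms from the ring nitrogen, can carry a group other than the one in compound 3 and still give a measured inhibition, and the true size of the step remains unknown. The recovery is only partial, with a 4.9-fold higher number from compound 2 to compound 4 (0.69 log units; beyond the scatter) and a 3.9-fold higher number from compound 1 to compound 4 (0.59 log units; beyond the scatter), which shows that (dimethylamino)methyl is set apart from both methanesulfonamido and cyclopentylamino in this assay, although those two groups lie within the scatter of each other.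

As far as these compounds go, what remains open is whether the gap to compound 1 and compound 2 belongs to the carbon link of the entering group or to its dimethylamino end. An aminomethyl group or a plain amine on the same aromatic carbon would bear on that question, and a carboxylic acid there would show how far the position accepts a quite different group.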